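Phenyl on the Thiourea Nitrogen: From Compound 2 to Compound 4

The compounds below may be only part of what the source reports. "The series", "measured", "known", "first", "only" and "open" are said of these compounds alone.

Measured in a functional assay on MCF7 cells (Homo sapiens) for antiproliferative activity, read by MTT assay, with a stated time of 72 h; a lower number here means a stronger inhibitor, a higher number a weaker inhibitor:
compound 1 `Oc1ccc2ccccc2c1/C=N/NC(=S)Nc1ccccc1` gives 3300 nM
compound 2 `CCN(CC)c1ccc(/C=N/NC(N)=S)c(O)c1` gives 400 nM
compound 3 `COc1cccc(/C=N/NC(N)=S)c1O` gives 300 nM

Three thiosemicarbazones have been tested so far. Among them compound 2 holds the second highest number: compound 3 sits at a slightly lower number, a gap that falls within the scatter of repeated measurements, so the two cannot be told apart; compound 1 sits at a much higher number, a gap that lies beyond the scatter, so compound 1 is the weaker inhibitor of that pair.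

Compound 4 `CCN(CC)c1ccc(/C=N/NC(=S)Nc2ccccc2)c(O)c1` has not yet been measured. It differs from compound 2 in one place: phenyl in place of hydrogen on an amide-type nitrogen. Compound 1 carries the same anilino group on a different core, and its number is the highest of the three, but no direct comparison of a single change is available, so the size of this step cannot be read from what is known.

The step from compound 2 to compound 4 is therefore an estimate rather than a reading. A modest shift toward a higher number, near the edge of the scatter, is expected, giving a 2.0-fold higher number from compound 2 to compound 4 (0.30 log units; within the scatter). For compound 4 the expected value in this assay is 800 nM, with a likely range from 250 nM to 2500 nM.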

Compound 4, half-maximal inhibitory concentration: 1200 nM
For compound 4 the middle estimate is 1.5-fold (0.18 log units) below the measured one; the range from low to high includes it.
By their numbers in this assay, from the lowest: compounds 3 and 2 (each within the scatter of the next); then compound 4; then compound 1.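

Putting phenyl in place of hydrogen on the amide-type nitrogen, the change from amino to anilino, gives a 3.0-fold higher number from compound 2 to compound 4 (0.48 log units; beyond the scatter) in this assay, which makes compound 4 the weaker inhibitor of this pair. Among the compounds shown here, compound 1 also carries the anilino group, but it has no partner differing from it in one place, so it could not show what this change does on its own; this pair is the first to give the change a size, and that size lies beyond the usual scatter of repeated measurements. Nothing shown here bears on why the phenyl group has this effect, so the result records the size of the step and leaves its cause unknown.

As far as these compounds go, this is a single step on a single core, so it remains open whether a methyl group, a longer chain such as butyl, or a phenyl ring carrying a carboxylic acid on the same nitrogen would give a step of similar size. From the compounds shown here alone, it is also open whether the change from amino to anilino would give a similar step on the core of compound 3, and so whether this result holds beyond one core.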